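The source may report more compounds than this note shows. Statements on the series, on what has been measured and on what is new or still open speak of the compounds shown alone.

For the measured compounds named here, in a functional assay on HepG2 cells (Homo sapiens) for cytotoxicity, read by MTT assay, with a stated time of 72 h (on this read-out lower numbers stand for stronger inhibition and higher numbers for weaker inhibition), three compounds built on a shared core have numbers so far. Compound 1 (`O=C(N/N=C/c1ccc(F)cc1Cl)Nc1cc2c(Nc3ccc(F)c(Cl)c3)ncnc2cc1O[C@H]1CCOC1`) gives 26100 nM, compound 2 (`COc1ccc(/C=N/NC(=O)Nc2cc3c(Nc4ccc(F)c(Cl)c4)ncnc3cc2O[C@H]2CCOC2)cc1`) gives 28800 nM, and compound 3 (`O=C(N/N=C/c1cc(Br)c(O)c(Br)c1)Nc1cc2c(Nc3ccc(F)c(Cl)c3)ncnc2cc1O[C@H]1CCOC1`) gives 2740 nM. Compound 2 stands at the high end of these numbers. That end is shared, with a 1.1-fold higher number from compound 1 to compound 2 (0.04 log units; within the scatter). Compound 4 (`O=C(N/N=C/c1ccc(O)cc1)Nc1cc2c(Nc3ccc(F)c(Cl)c3)ncnc2cc1O[C@H]1CCOC1`) alters compound 2 in one place: hydrogen in place of methyl on an oxygen on an aromatic ring, turning methoxy into hydroxy. The closest measured evidence is an 11-fold lower number from compound 2 to compound 3 (1.02 log units; beyond the scatter), where 3,5-dibromo-4-hydroxyphenyl replaces 4-methoxyphenyl. The similar a 9.5-fold lower number from compound 1 to compound 3 (0.98 log units; beyond the scatter) ends at the same compound. Those steps change more than the hydroxy, and the data cannot separate its share. A smaller step in the same direction is therefore expected, a 1.9-fold lower number from compound 2 to compound 4 (0.28 log units; within the scatter). For compound 4 the estimated value is 15000 nM, with an expected range of 5000 nM to 40000 nM.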

Compound 4, half-maximal inhibitory concentration: 70 nM
Estimate against measurement, compound 4: 210-fold (2.33 log units) above; the whole stated range lies above it.
By their numbers in this assay, from the lowest: compound 4; then compound 3; then compounds 1 and 2 (each within the scatter of the next).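

Changing methoxy to hydroxy removes only a methyl from this oxygen, yet it gives a 410-fold lower number from compound 2 to compound 4 (2.61 log units; beyond the scatter), so this one small group has a very large effect on the number. Replacing other rings with the plain 4-hydroxyphenyl also lowers the number, giving a 39-fold lower number from compound 3 to compound 4 (1.59 log units; beyond the scatter) when the two bromines are absent and a 370-fold lower number from compound 1 to compound 4 (2.57 log units; beyond the scatter) against the 2-chloro-4-fluorophenyl ring. Nothing measured here offers a reason for these drops. The compounds shown leave open how an amine or a carboxylic acid in place of the hydroxy, or a longer chain on the oxygen, would compare.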